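The compounds below may be only part of what the source reports. "The series", "measured", "known", "first", "only" and "open" are said of these compounds alone.

Measured compounds:
compound 1, `O=C(Nc1ccc(Oc2ccnc3[nH]ccc23)c(F)c1)c1cc(-c2ccccc2)ncn1`, 180 nM
compound 2, `O=C(Nc1ccc(Oc2ccnc3[nH]ccc23)c(F)c1)c1cc(-c2ccc(Cl)cc2)ncn1`, 3360 nM

In a functional assay on A549 cells (Homo sapiens) for cytotoxicity, read by MTT assay, with a stated time of 72 h (on this read-out lower numbers stand for stronger inhibition and higher numbers for weaker inhibition), compound 2 gives the higher of the two numbers recorded so far; its nearest neighbour is compound 1, and the change from one to the other was a 19-fold higher number from compound 1 to compound 2 (1.27 log units; beyond the scatter), a single substitution of chloro in place of hydrogen on an aromatic carbon. Compound 3, `O=C(Nc1ccc(Oc2ccnc3[nH]ccc23)c(F)c1)c1cc(-c2ccc(C(F)(F)F)cc2)ncn1`, has not yet been measured in this assay. It differs from compound 2 by trifluoromethyl in place of chloro on an aromatic carbon. Going by the values given here, the only measured step that bears on this place is the one from compound 1 to compound 2, which was large and ran toward weaker inhibition when a group was first put onto that aromatic carbon. That step concerns a different exchange, hydrogen to chloro, so it says little about exchanging one such group for another, and the expectation for compound 3 rests on thin ground. Compound 3 is therefore expected to sit near compound 2, with the step estimated as a 1.3-fold higher number from compound 2 to compound 3 (0.13 log units; within the scatter). For compound 3 the estimate in this assay is 4500 nM, with a range from 1200 nM to 16000 nM.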

Compound 3, half-maximal inhibitory concentration: 2220 nM
For compound 3 the middle estimate is 2.0-fold (0.31 log units) above the measured one, within the range that was stated.
By their numbers in this assay, from the lowest: compound 1; then compounds 3 and 2 (each within the scatter of the next).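

Within this assay, trifluoromethyl in place of chloro on this aromatic carbon, para to a large group, gives a step within the scatter (a 1.5-fold lower number from compound 2 to compound 3 (0.18 log units; within the scatter)), even though the entering group has 4 heavy atoms and the leaving group has 1. Set against the unsubstituted compound, the new group gives a large step (a 12-fold higher number from compound 1 to compound 3 (1.09 log units; beyond the scatter)), so the weaker inhibition first seen with chloro is not confined to that one group: both groups at this place lie well above compound 1 on this read-out. No accompanying measurement speaks to why these two groups behave alike here, and the result is left without an explanation.

With only chloro and trifluoromethyl compared against hydrogen, the compounds shown do not tell whether every group at this place would give a similar step, or whether a methyl, a methoxy, an amine or a carboxylic acid would stay closer to compound 1. They also leave open whether the same groups would give a large step when placed elsewhere on that ring.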